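Methoxy in Place of Bromo on the Aryl Piperidine

The source may hold more compounds than are shown below. What is called first, only, known or untested is meant among the compounds shown, and "the series" means these compounds.

Compound 1 `O=C1COc2ccc(NC(=O)C3CCN(c4cccc(Br)c4)CC3)cc2N1`: 330 nM
Compound 2 `O=C(Nc1cnc2ccccc2c1)C1CCN(c2cccc(C(F)(F)F)c2)CC1`: 600 nM
Compound 3 `CC(=O)N1CCc2cc(NC(=O)C3CCN(c4cccc(C(F)(F)F)c4)CC3)ccc21`: > 9000 nM

Of the compounds shown here, three share an aryl piperidine carboxamide and have been tested in a functional assay for antagonist activity at transient receptor potential cation channel subfamily V member 1 (Homo sapiens), read by FLIPR and calcium flux; on this read-out higher numbers stand for weaker inhibition and lower numbers for stronger inhibition. In this assay compound 1 gives 330 nM, the lowest of the two numbers shown. Compound 2 gives 600 nM, and this value lies within the scatter of that of compound 1, so the two cannot be told apart. For compound 3 this assay reports only a limit, > 9000 nM, rather than a number (the limit of > 9000 nM in this assay, at which 1 of the 3 values shown sits).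

Compound 4 `COc1cccc(N2CCC(C(=O)Nc3ccc4c(c3)NC(=O)CO4)CC2)c1` has not yet been measured. It differs from compound 1 in a single place: methoxy in place of bromo on an aromatic carbon. Within the data shown here, no pair of measured compounds shows this change, so its size is open here. The bromo has a known number on compound 1, and a methoxy in its place is expected to cost some inhibition. Compound 4 is expected to give 1000 nM, with a likely range from 300 nM to 4000 nM. That estimate means an expected step of a 3.0-fold higher number from compound 1 to compound 4 (0.48 log units; beyond the scatter), a moderate weakening that may prove to sit only at the edge of the scatter.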

Compound 4, half-maximal inhibitory concentration: 1420 nM
Beside the measured number, compound 4's estimate is 1.4-fold (0.15 log units) below it; measured number inside the range.
By their numbers in this assay, from the lowest: compounds 1 and 2 (each within the scatter of the next); then compound 4. At a limit, above all of these: compound 3.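

Among these compounds, until now, no two measured compounds differed in only one place, so no single group could be judged on its own. This pair gives the first such reading: in this assay, going from 3-bromophenyl to 3-methoxyphenyl gives a 4.3-fold higher number from compound 1 to compound 4 (0.63 log units; beyond the scatter), so the group at this aromatic carbon does matter, although the step is modest. The change replaces a single bromine atom with two heavy atoms, one of them a hydrogen-bond acceptor, and compound 4 still gives a measurable number rather than a limit.

Going by these compounds, how a chlorine atom, a methyl or an amine at this place would compare remains open, as does whether the same step would appear on a different core. Nothing measured here accounts for the size of this step.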